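Extending the piperidinyl chain on compound 3

The compounds below may be only part of what the source reports. "The series", "measured", "known", "first", "only" and "open" are said of these compounds alone.

In a functional assay on HEK293 cells for activation of 5-hydroxytryptamine receptor 4 (Homo sapiens), read by cAMP accumulation (on this read-out lower numbers stand for smaller maximal responses and higher numbers for larger maximal responses), compound 1 `COc1cc(N)c(Cl)cc1C(=O)NC1CCN(CCCCCO)CC1` gives > 100%, which is a limit of the assay and not a number. Compound 2 `COc1cc(N)c(Cl)cc1C(=O)NC1CCN(CCCCCCCCS(=O)(=O)O)CC1` gives > 100% in this assay, again a limit. Compound 3 `COc1cc(N)c(Cl)cc1C(=O)NC1CCN(CCCCCN2CCCCC2)CC1` gives > 100% in this assay, also a limit. All three values sit at the same place, (the limit of > 100% in this assay, at which 3 of the 3 values shown sit), so compound 3 stands level with the other two as far as the numbers allow. The steps among them, a step that the two limits leave unreadable from compound 1 to compound 2, a step that the two limits leave unreadable from compound 1 to compound 3 and a step that the two limits leave unreadable from compound 2 to compound 3, cannot be sized, since each one starts and ends at the limit.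

Compound 4 `COc1cc(N)c(Cl)cc1C(=O)NC1CCN(CCCCCCCCN2CCCCC2)CC1` carries the change (3-(piperidin-1-yl)propyl in place of piperidin-1-yl on a saturated chain carbon, five bonds along the chain from an amine nitrogen in a ring). Within the data shown here, the steps that bear on it are the three above: each exchanges the end group on the same chain carbon, and each stays at the limit without a readable size. The step expected in this assay, a number no higher from compound 3 to compound 4 (the limit leaves the size open), is therefore none beyond the scatter, and compound 4 is expected most likely to be reported at the limit as well. For compound 4 the estimate in this assay is 100%, with a range from 85% to 115%.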

Compound 4, intrinsic activity: the largest response reached, in percent of the reference agonist's: > 100%
Compound 4 ended at the assay's limit; the forecaster's own chance of this, stated with the estimate: 70%; the middle value lies on the limit itself.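

In this assay compound 4 gives > 100%, a limit of the assay and not a number. No step from compound 1, compound 2 or compound 3 to compound 4 can be read: the limit of > 100% in this assay, at which 4 of the 4 values shown sit.

Whether the end groups or chain lengths differ at all in maximal response stays open, with no compound shown giving a number.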